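Swapping Carbamoyl for Ethoxy on the Phenylpiperazine

This account rests on a few compounds, and the source may have more. Where it says the series, first, only, none or still open, it means among the compounds named here.

Compound 1 `Cc1nc(-c2ccccc2)c(C(=O)N2CCN(c3cccc(C(N)=O)c3)CC2)o1`: 71 nM
Compound 2 `CCc1nc(-c2ccc(C(C)C)cc2)c(C(=O)N2CCN(c3cccc(OC)c3)CC2)o1`: 887 nM
Compound 3 `Cc1ccc(C)c(N2CCN(C(=O)c3oc(C)nc3-c3cccc(F)c3)CC2)c1`: 204 nM

In a functional assay on HL-60 cells (Homo sapiens) for inhibition, read by MTT assay, with a stated time of 72 h (a higher number here means a weaker inhibitor, a lower number a stronger inhibitor), compound 1 stands lowest of the three measured numbers, so it is the strongest inhibitor here. Compound 3 is nearest to it, yet its gap lies beyond the scatter, and compound 2 is furthest away. Compound 4 `CCOc1cccc(N2CCN(C(=O)c3oc(C)nc3-c3ccccc3)CC2)c1` is not yet measured. It differs from compound 1 in one place: ethoxy in place of carbamoyl on an aromatic carbon. Going by the values given here, no measured pair shows this change on its own. Compound 2 carries a methoxy on the same ring together with other changes, and its number is well above that of compound 1. Compound 4 is therefore expected to be a somewhat weaker inhibitor than compound 1, with the step of a 3.1-fold higher number from compound 1 to compound 4 (0.49 log units; beyond the scatter) expected to lie beyond the scatter. The estimate for compound 4 is 220 nM, in the range 60 nM to 800 nM.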

Compound 4, half-maximal inhibitory concentration: 151 nM
Beside the measured number, compound 4's estimate is 1.5-fold (0.16 log units) above it; low and high end bracket the measured number.
By their numbers in this assay, from the lowest: compound 1; then compounds 4 and 3 (each within the scatter of the next); then compound 2.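

Changing 3-carbamoylphenyl to 3-ethoxyphenyl with nothing else altered gives, in this assay, a 2.1-fold higher number from compound 1 to compound 4 (0.33 log units; beyond the scatter) as a modest loss. The amide's hydrogen-bond donor can therefore go from this aromatic carbon at only a small cost, and the ethoxy compound remains a sub-micromolar inhibitor. Nothing available explains the size of this step.

On these data alone, whether a carboxylic acid or an aminomethyl group on the same carbon would keep this level of inhibition remains open. Also open, as far as these compounds go, is whether the step would hold with other groups elsewhere on the core.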